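Pyrazoline amides: shifting the benzodioxin attachment point

This account rests on a few compounds, and the source may have more. Where it says the series, first, only, none or still open, it means among the compounds named here.

Measured so far:
Compound 1, `COc1ccc(C2CC(c3ccccc3)=NN2C(=O)c2ccc3c(c2)OCCO3)cc1`: 8370 nM
Compound 2, `O=C(c1ccc2c(c1)OCCO2)N1N=C(c2ccccc2)CC1c1ccccc1`: 1370 nM

In a functional assay on WM 266-4 cells (Homo sapiens) for inhibition, read by MTT assay, with a stated time of 24 h (a lower number here means a stronger inhibitor of growth, a higher number a weaker inhibitor of growth), compound 1 gives 8370 nM, the highest of the two numbers. Its nearest neighbour is compound 2 with 1370 nM, reached through a 6.1-fold lower number from compound 1 to compound 2 (0.79 log units; beyond the scatter), a change at the methoxy site rather than at the carbonyl. Compound 3, `COc1ccc(C2CC(c3ccccc3)=NN2C(=O)C2COc3ccccc3O2)cc1`, differs from compound 1 by 2,3-dihydro-1,4-benzodioxin-2-yl in place of 2,3-dihydro-1,4-benzodioxin-6-yl on a carbonyl carbon. Within the data shown here, no measured step alters the group on the carbonyl carbon, so nothing here bears directly on this change. For compound 3 the expected step is a 1.0-fold lower number from compound 1 to compound 3 (0.02 log units; within the scatter), none beyond the scatter, with wide uncertainty. Compound 3 is therefore estimated at 8000 nM, with a range from 2500 nM to 25000 nM.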

Compound 3, concentration for 50% growth inhibition: 5080 nM
Beside the measured number, compound 3's estimate is 1.6-fold (0.20 log units) above it, within the range that was stated.
By their numbers in this assay, from the lowest: compound 2; then compounds 3 and 1 (each within the scatter of the next).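

In this assay, among these compounds, exchanging 2,3-dihydro-1,4-benzodioxin-6-yl for 2,3-dihydro-1,4-benzodioxin-2-yl on the carbonyl carbon gives a 1.6-fold lower number from compound 1 to compound 3 (0.22 log units; within the scatter), the first reading at this position. These two attachment points are therefore not told apart in this series, and the carbonyl position tolerates this change on the core of compound 1. No supporting evidence bears on this result.

Still open, on these data alone, is whether hydrogen in place of methoxy, worth a 6.1-fold lower number from compound 1 to compound 2 (0.79 log units; beyond the scatter) with the 6-yl group, carries over to the 2-yl group. Also open, as far as these compounds go, is how an amine or a carboxylic acid on the carbonyl carbon would read.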